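This account rests on a few compounds, and the source may have more. Where it says the series, first, only, none or still open, it means among the compounds named here.

Measured so far in an assay on HEK293 cells for displacement of a labelled ligand from growth hormone secretagogue receptor type 1 (Homo sapiens), with a stated time of 60 min; a lower number here means a stronger inhibitor, a higher number a weaker inhibitor:
compound 1, `CS(=O)(=O)c1ccc2sc(NC(=O)NC(=O)c3ccccc3Cl)nc2c1`, 4700 nM
compound 2, `CC(C)NCCS(=O)(=O)c1ccc2nc(NC(=O)NC(=O)c3ccccc3Cl)sc2c1`, 27 nM
compound 3, `CN1CCC(S(=O)(=O)c2ccc3nc(NC(=O)NC(=O)c4cc(N5CCCC5)c(C#N)cc4Cl)sc3c2)CC1`, 0.4 nM

Compound 2 stands second highest of the three numbers. Compound 3 gives the nearest number, lower than compound 2 and beyond the scatter; compound 1 gives the furthest, higher than compound 2 and also beyond the scatter. Going by the values given here, no pair of these differs in one place only, so nothing is known of single steps.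

Compound 4, `CN1CCCN(CCCS(=O)(=O)c2ccc3nc(NC(=O)NC(=O)c4ccccc4Cl)sc3c2)CC1`, has not been measured. It differs from compound 2 in one place: (4-methyl-1,4-diazepan-1-yl)methyl in place of isopropylamino on a saturated chain carbon, two bonds along the chain from a sulfonyl sulfur. The cyclic amine in compound 3 goes with the lowest number seen, but other changes accompany it there, so the step from compound 2 to compound 4 is expected to be small, perhaps a modest lowering or none beyond the scatter, as a 1.8-fold lower number from compound 2 to compound 4 (0.26 log units; within the scatter). Compound 4 is estimated at 15 nM, within 4 nM to 60 nM.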

Compound 4, half-maximal inhibitory concentration in the growth hormone secretagogue receptor type 1 assay: 4.2 nM
The estimate for compound 4 lay 3.6-fold (0.55 log units) above the measured number; the measured number falls inside the stated range.
By their numbers in the growth hormone secretagogue receptor type 1 assay, from the lowest: compound 3; then compound 4; then compound 2; then compound 1.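

In the growth hormone secretagogue receptor type 1 assay, a 6.4-fold lower number from compound 2 to compound 4 (0.81 log units; beyond the scatter) shows that the chain on the sulfonyl sulfur accepts (4-methyl-1,4-diazepan-1-yl)methyl in place of isopropylamino, with the number falling beyond the scatter on the otherwise unchanged core. In a physicochemical assay for solubility, at pH 7.4 (on this read-out higher numbers stand for higher solubility and lower numbers for lower solubility), compound 2 gives 71000 nM and compound 4 gives 340000 nM. The same change therefore goes with higher solubility as well as a lower binding number: the measured solubility of compound 2, 71000 nM, and of compound 4, 340000 nM, a 4.8-fold higher number (0.68 log units; beyond the scatter)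

Still open, on these data alone, is which part of the change carries the step: the seven-membered ring, the second nitrogen or the longer chain. A piperazine ring or a 3-(dimethylamino)propyl chain at this position would help separate these.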